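Halogen swap on the pendant phenyl of compound 3

This account rests on a few compounds, and the source may have more. Where it says the series, first, only, none or still open, it means among the compounds named here.

Compound 3 `CC(=O)Nc1cccc(C2CCN(CCCn3c(-c4ccc(C#N)cc4)nc4ccccc43)CC2)c1` is the cyano-bearing member of the series; in an assay for displacement of a labelled ligand from melanin-concentrating hormone receptor 1 (Homo sapiens), read by fluorescence (on this read-out higher numbers stand for weaker inhibition and lower numbers for stronger inhibition), compound 3 gives 16 nM. Among the three measured compounds this places compound 3 second highest: compound 2 `CC(=O)Nc1cccc(C2CCN(CCCn3c(-c4ccc(Br)cc4)nc4ccccc43)CC2)c1` gives 5 nM and the bromo-to-cyano step is a 3.2-fold higher number from compound 2 to compound 3 (0.51 log units; beyond the scatter), while compound 1 `COc1ccccc1-c1nc2ccccc2n1CCCN1CCC(c2cccc(NC(C)=O)c2)CC1` gives 747 nM, and the steps to compound 2 and compound 3 are a 150-fold lower number from compound 1 to compound 2 (2.17 log units; beyond the scatter) and a 47-fold lower number from compound 1 to compound 3 (1.67 log units; beyond the scatter).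

Compound 4 `CC(=O)Nc1cccc(C2CCN(CCCn3c(-c4ccc(Cl)cc4F)nc4ccccc43)CC2)c1` arises from compound 3 by 4-chloro-2-fluorophenyl in place of 4-cyanophenyl on an aromatic carbon. The step that bears on this is the bromo-to-cyano change, a 3.2-fold higher number from compound 2 to compound 3 (0.51 log units; beyond the scatter), which says a halogen at this position gives a modestly lower number than the nitrile. Chloro is the nearer relative of bromo; the additional fluorine has no measured counterpart in the series, so its effect is unknown. On balance, a modest lowering is expected for compound 4, with a 2.3-fold lower number from compound 3 to compound 4 (0.36 log units; beyond the scatter), putting compound 4 in this assay at an estimated 7 nM within a range from 2 nM to 25 nM.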

Compound 4, half-maximal inhibitory concentration: 1 nM
Compound 4: the middle estimate sits 7.0-fold (0.85 log units) above what was measured, and the stated range ends above it.
By their numbers in this assay, from the lowest: compound 4; then compound 2; then compound 3; then compound 1.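

In this assay the 4-chloro-2-fluorophenyl group gives the lowest number in the series, with a 16-fold lower number from compound 3 to compound 4 (1.20 log units; beyond the scatter) and a 5.0-fold lower number from compound 2 to compound 4 (0.70 log units; beyond the scatter), so at this position it goes beyond both the nitrile and the bromo compound. With a 750-fold lower number from compound 1 to compound 4 (2.87 log units; beyond the scatter), the high number seen with 2-methoxyphenyl does not extend to 4-chloro-2-fluorophenyl, although both names carry a group at 2. No measurement shown here accounts for the size of these steps.

The compounds shown do not separate the contribution of the chlorine from that of the fluorine, as neither 4-chlorophenyl nor 2-fluorophenyl stands among them. On these data alone, how 4-aminophenyl or 4-carboxyphenyl would read at this position also remains open.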